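This account rests on a few compounds, and the source may have more. Where it says the series, first, only, none or still open, it means among the compounds named here.

Measured so far:
compound 1, `O=C(c1ccccc1F)N1CC[C@H]1c1nc(-c2cccc(F)c2)no1` — 920 nM
compound 2, `Cc1ccc(S(=O)(=O)N2CC(c3nc(-c4cccc(Cl)c4)no3)C2)cc1` — 920 nM

In an assay on HEK293 cells for negative allosteric modulation of metabotropic glutamate receptor 5 (Homo sapiens), read by FLIPR (on this read-out higher numbers stand for weaker inhibition and lower numbers for stronger inhibition), compound 1 gives 920 nM. Compound 2 carries a different substituent on the shared core and a chloro in place of fluoro on the pendant phenyl; in this assay compound 2 gives 920 nM, level with compound 1 at the digits shown, so the two sit within the usual scatter of each other. Among the measured compounds shown here, the two compounds differ in more than one place, and no single-position step between them is available; their values alone show no separation.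

Compound 3, `O=S(=O)(c1ccc(Cl)cc1)N1CC(c2nc(-c3cccc(Cl)c3)no2)C1`, is not yet measured. It differs from compound 2 by chloro in place of methyl on an aromatic carbon, para to a large group. Nothing in the measured pair bears directly on this exchange, so the expectation for the step from compound 2 to compound 3 is none beyond the scatter, in either direction. The estimated step, a 1.1-fold lower number from compound 2 to compound 3 (0.03 log units; within the scatter), is accordingly expected to be small. Compound 3 is expected to give about 850 nM in this assay, with a likely range from 300 nM to 2500 nM.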

Compound 3, half-maximal inhibitory concentration: 170 nM
The estimate for compound 3 lay 5.0-fold (0.70 log units) above the measured number; measured number outside the range, below it.
By their numbers in this assay, from the lowest: compound 3; then compounds 1 and 2 (each within the scatter of the next).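

In this assay the exchange of 4-methylphenyl for 4-chlorophenyl gives a 5.4-fold lower number from compound 2 to compound 3 (0.73 log units; beyond the scatter) and so shows that this position, on an aromatic carbon para to a large group, is not indifferent to the group it carries. Among the compounds shown here, the earlier values offered no single-position step; here one heavy atom replaces another, with no ring, hydrogen-bond donor, hydrogen-bond acceptor or net charge entering or leaving, and the number still moves beyond the scatter. Nothing measured here accounts for the size or direction of this step.

The compounds shown leave open how a methoxy group, an amine or a carboxylic acid at this position would compare with methyl and chloro, so one exchange gives the direction for this pair only and no trend across substituents. On these data alone, it also remains open whether the chloro on the pendant phenyl, common to compound 2 and compound 3, has any part in the size of the step, or whether the same exchange would give a similar step with another group on that phenyl.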